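A few compounds are considered here, and "the series" means these few. Any claim that something is new, unique, unknown or untested is made for them only; others in the source may bear on it.

Compound 1 `COc1ccc(Cn2c(C(=O)N3CCCCC3)cc3sccc32)cc1`: > 100000 nM
Compound 2 `COc1ccc(Cn2c(C(=O)N3CCC(C(=O)O)CC3)cc3sccc32)cc1`: > 100000 nM
Compound 3 `COc1ccc(Cn2c(C(=O)N3CCC(C(=O)NC4CC4)CC3)cc3sccc32)cc1`: 21400 nM

These results come from an ADME assay on HEK-293T cells (Homo sapiens) for cytotoxicity, read by luminescence, with a stated time of 24 h; on this read-out higher numbers stand for lower toxicity in this test and lower numbers for higher toxicity in this test. Compound 1 sits at a limit of the assay, not a true number. Compound 2 sits at that same limit. Only compound 3 has a true number, 21400 nM.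

Compound 4 `COc1ccc(Cn2c(C(=O)N3CCC(C(=O)NCC4CC4)CC3)cc3sccc32)cc1` carries one change: cyclopropylmethyl in place of cyclopropyl on an amide-type nitrogen. Two measured steps introduced the cyclopropylcarbamoyl group, an at least 4.6-fold lower number from compound 1 to compound 3 (0.66 log units; beyond the scatter) and an at least 4.6-fold lower number from compound 2 to compound 3 (0.66 log units; beyond the scatter). Going by these compounds, both are bounded by the limit, so their full size is unknown. Neither compares one amide nitrogen substituent with another, so they offer no reason to expect a large shift. The expected result is no change beyond the scatter, a 1.1-fold lower number from compound 3 to compound 4 (0.03 log units; within the scatter). Compound 4 is estimated at 20000 nM, within an expected range of 9000 nM to 45000 nM.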

Compound 4, half-maximal cytotoxic concentration: 24600 nM
Estimate against measurement, compound 4: 1.2-fold (0.09 log units) below; low and high end bracket the measured number.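

Cyclopropylmethyl in place of cyclopropyl on the amide-type nitrogen gives a 1.1-fold higher number from compound 3 to compound 4 (0.06 log units; within the scatter), so this position accepts that change without a shift beyond the scatter. The lower number is therefore not confined to the cyclopropyl amide of compound 3, as shown by an at least 4.0-fold lower number from compound 2 to compound 4 (0.60 log units; beyond the scatter) and an at least 4.0-fold lower number from compound 1 to compound 4 (0.60 log units; beyond the scatter). Compound 1 and compound 2 sit at a limit, so the full size of those two steps stays unknown: the limit of > 100000 nM in this assay, at which 2 of the 4 values shown sit.

Going by these compounds, whether a longer chain on that nitrogen, or a chain ending in an amine, would move the number beyond the scatter remains open.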